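One Changed Stereocentre in a Series at the Limit

This account rests on a few compounds, and the source may have more. Where it says the series, first, only, none or still open, it means among the compounds named here.

In a functional assay on QGY cells (Homo sapiens) for cytotoxicity, read by MTT assay, with a stated time of 48 h (a higher number here means a weaker inhibitor, a lower number a stronger inhibitor), compound 1 (`CCOC(=O)[C@@]1(C(=O)Nc2ccccc2)C[C@@H]1c1cc(OC)c(OC)c(OC)c1`) gives > 100000 nM, which is a limit of the assay and not a number. Compound 2 (`CCOC(=O)[C@@]1(C(=O)Nc2ccccc2Cl)C[C@@H]1c1cc(OC)c(OC)c(OC)c1`) gives > 100000 nM, also a limit. Compound 3 (`CCOC(=O)[C@@]1(C(=O)NCc2ccc(C)cc2)C[C@@H]1c1cc(OC)c(OC)c(OC)c1`) gives > 100000 nM, again a limit. Compound 1 therefore has no exact number, and the whole set shares one reading: the limit of > 100000 nM in this assay, at which 3 of the 3 values shown sit.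

Compound 4 (`CCOC(=O)[C@@]1(C(=O)Nc2ccccc2)C[C@H]1c1cc(OC)c(OC)c(OC)c1`) is built from the same pieces as compound 1: the two compounds have the same atoms and bonds and differ only in configuration as drawn: 1 of 2 stereo elements differ; a stereocentre at a saturated ring carbon is drawn R in compound 1 and S in compound 4. Nothing leaves and nothing enters, since the two compounds have the same atoms and bonds and differ only in configuration as drawn.

The measured steps are a step that the two limits leave unreadable from compound 1 to compound 2, a step that the two limits leave unreadable from compound 1 to compound 3 and a step that the two limits leave unreadable from compound 2 to compound 3. None has a readable size, and each swaps a group rather than a configuration, so they give no measured size for this kind of change. The expectation rests on compound 1 sitting at > 100000 nM, a limit, and no clear move in either direction can be foreseen. The expected step, beyond nothing more than the usual scatter, is a number no higher from compound 1 to compound 4 (the limit leaves the size open). The assay will most likely report only a limit again. For compound 4 the estimated value is 100000 nM, with an expected range from 30000 nM to 200000 nM.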

Compound 4, half-maximal inhibitory concentration: 48700 nM
Compound 4: middle estimate off by 2.1-fold (0.31 log units), on the high side, within the range that was stated.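

Among the compounds shown here, changing the configuration of one stereocentre at a saturated ring carbon, drawn R and then S, is enough for an at least 2.0-fold lower number from compound 1 to compound 4 (0.31 log units; beyond the scatter) in this assay, which makes this the first change with a readable effect. With no atom or bond gained or lost, this shift can be traced to the drawn configuration at that carbon alone: the fact that compounds 1 and 4 differ only in the configuration as drawn. Compound 1 gives > 100000 nM, which is a limit, so the size of this step is only a lower bound, and the three earlier steps, all running between limits, cannot be read.

The compounds shown leave open whether the same S configuration at this carbon would also bring compound 2 or compound 3 off the limit, given that only the phenyl amide of compound 1 appears here in both configurations. They also leave open how the value of compound 4 would respond if a carboxylic acid stood in place of the ethyl ester, or if a longer chain joined the amide nitrogen to the phenyl ring.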